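Cytotoxicity notes: fluoro to trifluoromethyl

The compounds below may be only part of what the source reports. "The series", "measured", "known", "first", "only" and "open" are said of these compounds alone.

In an ADME assay on MT4 cells (Homo sapiens) for cytotoxicity, read by MTT assay, with a stated time of 4 days (a lower number here means that less compound is tolerated, a higher number that more compound is tolerated), compound 1 (`CC(=O)Nc1ccc(O)c(C(=O)/C=C/c2ccccc2F)c1`) gives 33800 nM and compound 2 (`CC(=O)Nc1ccc(O)c(C(=O)/C=C/c2ccc(F)cc2)c1`) gives 41100 nM with the two values within the scatter of each other. Within the data shown here, the only measured step (a 1.2-fold higher number from compound 1 to compound 2 (0.08 log units; within the scatter)) stays within the scatter and merely moves the fluoro group. Among the measured compounds shown here, compound 3 (`CC(=O)Nc1ccc(O)c(C(=O)/C=C/c2ccc(C(F)(F)F)cc2)c1`) carries trifluoromethyl in place of fluoro on an aromatic carbon and no measured step covers that exchange. On this thin basis no step beyond the scatter is expected in this assay for the exchange. The estimated step (a 1.2-fold lower number from compound 2 to compound 3 (0.10 log units; within the scatter)) is expected to stay within the scatter. Compound 3 is estimated at 33000 nM with an expected range from 14000 nM to 70000 nM for now.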

Compound 3, half-maximal cytotoxic concentration: 21100 nM
Beside the measured number, compound 3's estimate is 1.6-fold (0.19 log units) above it, and the stated range covers the measured number.
By their numbers in this assay, from the lowest: compounds 3, 1 and 2 (each within the scatter of the next).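

In this assay, the exchange of fluoro for trifluoromethyl on the aromatic carbon para to a large group gives a 1.9-fold lower number from compound 2 to compound 3 (0.29 log units; within the scatter). So far, then, this position tolerates an exchange of the group itself without a step beyond the scatter, which the earlier move of fluoro could not show. No evidence on any cause is available.

As far as these compounds go, whether an amine, a carboxylic acid or a longer chain at this place would give a step beyond the scatter stays open. So does the reading of trifluoromethyl elsewhere on this ring.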